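The compounds below may be only part of what the source reports. "The series", "measured", "known", "first", "only" and "open" are said of these compounds alone.

Measured so far in a functional assay on DU-145 cells (Homo sapiens) for antiproliferative activity, read by CCK-8 assay, with a stated time of 72 h (a lower number here means a stronger inhibitor, a higher number a weaker inhibitor), as follows:
compound 1 `Cc1cc(Nc2cc(N3CCN(C)CC3)nc(Nc3ccc(S(N)(=O)=O)cc3)n2)n[nH]1` gives 926 nM
compound 2 `Cc1cc(Nc2cc(N3CCN(C)CC3)nc(Nc3ccc([N+](=O)[O-])cc3)n2)n[nH]1` gives 1200 nM

Compound 2 and compound 1 lie within the scatter of each other, so these two numbers give compound 2 no distinct place in the series. Next comes compound 3 `Cc1cc(Nc2cc(N3CCN(C)CC3)nc(Nc3ccc(Cl)cc3)n2)n[nH]1` with the change chloro in place of nitro on an aromatic carbon relative to compound 2. Among the measured compounds shown here, one measured step bears on this carbon, nitro in place of sulfamoyl, and its size is a 1.3-fold higher number from compound 1 to compound 2 (0.11 log units; within the scatter) with nothing larger seen there so far. For the measured compounds named here, no measured compound carries chloro, and a single step is thin evidence, so the range stays wide. No step beyond the scatter is expected in this assay in either direction. The estimated step is a 1.2-fold lower number from compound 2 to compound 3 (0.08 log units; within the scatter) and remains only an expectation. Compound 3 is estimated at 1000 nM with an expected range of 400 nM to 2500 nM for now.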

Compound 3, half-maximal inhibitory concentration: 2240 nM
Compound 3: middle estimate off by 2.2-fold (0.35 log units), on the low side, and the stated range covers the measured number.
By their numbers in this assay, from the lowest: compounds 1, 2 and 3 (each within the scatter of the next, the first and the last beyond it).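

Sulfamoyl and chloro on this aromatic carbon now give the first step at this position that lies beyond the scatter in this assay (a 2.4-fold higher number from compound 1 to compound 3 (0.38 log units; beyond the scatter)), although it is a modest one. Chloro in place of nitro does not separate the pair (a 1.9-fold higher number from compound 2 to compound 3 (0.27 log units; within the scatter)), so compound 2 cannot be ordered against either neighbour, and the three groups do not form a clear ranking. The measured data offer no explanation for the difference between sulfamoyl and chloro.

Still open, as far as these compounds go, is whether an amine, a carboxylic acid, a methoxy group or a longer chain on this aromatic carbon would produce a larger step than those seen so far. Also open, from the compounds shown here alone, is whether the plain phenyl ring, with hydrogen in this place, would fall within the scatter of these three compounds.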